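Inverting one chain stereocentre: notes on compound 4

This account rests on a few compounds, and the source may have more. Where it says the series, first, only, none or still open, it means among the compounds named here.

Values in a functional assay on A2780 ADR cells (Homo sapiens) for cytotoxicity, read by MTT assay, with a stated time of 24 h (a lower number here means a stronger inhibitor, a higher number a weaker inhibitor), so far
compound 1 `CCCCC[C@H](CCC[C@@H]1CC=CC(=O)O1)OC` gives 20500 nM
compound 2 `CCCCC[C@@H](C[C@H](O)C[C@@H]1CC=CC(=O)O1)OC` gives 26300 nM
compound 3 `CCCCC[C@H](C[C@@H](O)C[C@@H]1CC=CC(=O)O1)OC` gives 91500 nM

Compound 1 and compound 2 lie within the scatter of each other at the low end of this short series, while compound 3 stands apart (a 4.5-fold higher number from compound 1 to compound 3 (0.65 log units; beyond the scatter)). Compound 4 `CCCCC[C@@H](CCC[C@@H]1CC=CC(=O)O1)OC` has not yet been measured and differs from compound 1 in configuration only (the two compounds have the same atoms and bonds and differ only in configuration as drawn: 1 of 2 stereo elements differ; a stereocentre at a saturated chain carbon is drawn R in compound 1 and S in compound 4). Within the data shown here, the one measured change of configuration separates compound 2 from compound 3 (a 3.5-fold higher number from compound 2 to compound 3 (0.54 log units; beyond the scatter)), a modest step that can be read as a configuration effect given the fact that compounds 2 and 3 differ only in the configuration as drawn and that alters more stereo elements than the change to compound 4 does. The hydroxy step bears less on this case, as no hydroxy enters or leaves. The stereocentre in question is drawn S in compound 2 and compound 4, and R in compound 1 and compound 3. A small shift to a lower number is therefore expected in this assay, smaller than the step to compound 3 from compound 2 and probably not beyond the scatter. The estimated step is small (a 1.2-fold lower number from compound 1 to compound 4 (0.08 log units; within the scatter)). For compound 4 the expected value is 17000 nM with an estimated range from 7000 nM to 40000 nM at its ends.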

Compound 4, half-maximal inhibitory concentration: 11500 nM
Beside the measured number, compound 4's estimate is 1.5-fold (0.17 log units) above it, and the stated range covers the measured number.
By their numbers in this assay, from the lowest: compounds 4, 1 and 2 (each within the scatter of the next, the first and the last beyond it); then compound 3.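

Inverting this one chain stereocentre, with no hydroxy on the chain, gives a 1.8-fold lower number from compound 1 to compound 4 (0.25 log units; within the scatter) in this assay, so this centre alone has not been shown to shift the number beyond the scatter: the fact that compounds 1 and 4 differ only in the configuration as drawn

The hydroxy change can now be read with this centre in either configuration, and hydrogen in place of hydroxy gives a 2.3-fold lower number from compound 2 to compound 4 (0.36 log units; beyond the scatter), a step that agrees in direction and, within the scatter, in size with the earlier one: the same change on two cores in this assay, a 4.5-fold higher number (0.65 log units; beyond the scatter) from compound 1 to compound 3 and a 2.3-fold higher number (0.36 log units; beyond the scatter) from compound 4 to compound 2, 2.0-fold (0.29 log units) apart, within the scatter of two such steps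

Set against a 3.5-fold higher number from compound 2 to compound 3 (0.54 log units; beyond the scatter), where two stereo elements differ with the hydroxy present, the single inversion does not account for that step on its own, and the data cannot tell whether the remainder lies with the hydroxy-bearing carbon or with the two centres together: the fact that compounds 2 and 3 differ only in the configuration as drawn

No pair shown differs at the hydroxy-bearing carbon alone, and its separate contribution remains open. Also open, from the compounds shown here alone, is whether an amine in place of the hydroxy, or a longer chain, would follow the same steps on either configuration.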